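The source may report more compounds than this note shows. Statements on the series, on what has been measured and on what is new or still open speak of the compounds shown alone.

Measured so far:
compound 1 `CC(C)N(Cc1cccc(OCCCCCC(=O)O)c1)C(=O)c1ccc(-c2ccc3c(c2)OCCO3)cc1` — > 21900 nM
compound 2 `CCOC(=O)CCCCCOc1ccc(CNC(C)C)cc1` — > 26000 nM

Both of these results are limits of the assay rather than numbers. In an ADME assay on Raji cells (Homo sapiens) for cytotoxicity, read by CellTiter-Glo and resazurin assay, with a stated time of 72 h (on this read-out lower numbers stand for an effect already at smaller amounts and higher numbers for an effect only at larger amounts of compound), compound 1 reaches only the limit (the limit of > 21900 nM in this assay, at which 1 of the 2 values shown sits). In this assay compound 2 likewise gives only the limit (the limit of > 26000 nM in this assay, at which 1 of the 2 values shown sits), so compound 2 stands at the top of what this assay can report, with no effect seen up to the highest amount tested. Nothing measured here separates the two compounds; both simply sit at their limits.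

Compound 3 `CCOC(=O)CCCCCOc1ccc(CO)cc1` has not been measured. It differs from compound 2 in one place: hydroxy in place of isopropylamino on a saturated chain carbon bound to an aromatic carbon, a hydroxy in place of isopropylamino on a saturated chain carbon bound to an aromatic carbon. With no measured step of this kind among the compounds shown, and with compound 2 already at a limit, the step from compound 2 to compound 3 is expected to be a step that the limit leaves unreadable from compound 2 to compound 3, that is, none beyond the usual scatter. Compound 3 is therefore expected to give about 30000 nM in this assay, within a range from 8000 nM to 120000 nM, most likely again reported only as a limit.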

Compound 3, half-maximal effective concentration: > 27100 nM
Compound 3: no number, only a limit; the forecaster's own chance of this, stated with the estimate: 85%; the middle value lies beyond the limit too.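

In this assay compound 2 and compound 3 both give only limits, not numbers, so the change from isopropylamino to hydroxy cannot be read as a step of any size. The compounds shown leave open at what amount, if any, each compound would affect these cells, and whether that change matters at all.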